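Allyl in Place of Nitrile on the Ether Chain

The source may hold more compounds than are shown below. What is called first, only, known or untested is meant among the compounds shown, and "the series" means these compounds.

Compound 1 `C=CCc1cc(C(C)=O)c(O)cc1OCCCC#N` gives 6% in an assay on isolated protein for binding affinity to leukotriene B4 receptor 1 (Homo sapiens), tested at 1 uM (on this read-out higher numbers stand for more inhibition at the one concentration tested (going by the name of the read-out) and lower numbers for less inhibition), the lower of the two numbers in hand, while compound 2 `CCc1cc(C(C)=O)c(O)cc1OCCCCCCCC(C)(C)C#N` gives 29% in this assay, a gap beyond the scatter. Compound 3 `C=CCCCCOc1cc(O)c(C(C)=O)cc1CC=C` has not yet been tested in this assay. It differs from compound 1 in one place: allyl in place of cyano on a saturated chain carbon, three bonds along the chain from an oxygen on an aromatic ring. For the measured compounds named here, no measured pair shows this change, so its size is uncertain; a modest rise in this assay is expected, though possibly none beyond the scatter. The expected step is a number 9 percentage points higher from compound 1 to compound 3 (within the scatter). For compound 3 the estimate in this assay is 15%, with a range from 0% to 35%.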

Compound 3, a percentage reported as inhibition, at one concentration (the size of the read-out at that concentration, not a potency): 27%
Compound 3: the middle estimate sits 12 percentage points below what was measured; measured number inside the range.
By their numbers in this assay, from the lowest: compound 1; then compounds 3 and 2 (each within the scatter of the next).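

Replacing cyano with allyl at this place on the chain gives the first measured size for this change: in this assay the number rises a number 21 percentage points higher from compound 1 to compound 3 (beyond the scatter) at the one concentration tested. A nitrile at the chain end is therefore not required for this level of inhibition, since hex-5-en-1-yl can stand in for 3-cyanopropyl. No measurement available explains the rise. From the compounds shown here alone, whether a saturated hexyl chain would do the same remains open, as does the effect of an amine or a carboxylic acid at the chain end.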